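The source may report more compounds than this note shows. Statements on the series, on what has been measured and on what is new or still open speak of the compounds shown alone.

Working notes on a short series tested in an assay on isolated protein for inhibition of Phenylethanolamine N-methyltransferase (Bos taurus); on this read-out lower numbers stand for stronger inhibition and higher numbers for weaker inhibition. The reference aldehyde compound 1 `O=CC1CCCCCCCC1` gives 6000 nM in this assay. The two silyl cyanohydrins carry a nitrile and a silyl ether on one chain carbon, with a saturated chain attached: compound 2 `CCCCCC(C#N)O[Si](C)(C)C` gives 314000 nM, and compound 3 `CCCCCCC(C#N)O[Si](C)(C)C` gives 109000 nM. Among the three numbers compound 3 stands second highest; its nearest neighbour is compound 2, and the widest gap separates it from compound 1, whose number is far lower. For the measured compounds named here, the one single-point step measured so far is the chain extension, a 2.9-fold lower number from compound 2 to compound 3 (0.46 log units; beyond the scatter), a modest lowering that lies beyond the scatter.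

The next member, compound 4 `CCCCCCCC(C#N)O[Si](C)(C)C`, repeats that pattern one carbon further along: methyl in place of hydrogen on a saturated chain carbon, seven bonds along the chain from an oxygen on an unsaturated carbon and a triple-bonded carbon. Going by the values given here, only the step from compound 2 to compound 3 bears on it, and it points to a lowering of similar size, with no second example to show whether the effect carries on or flattens. A further modest fall is therefore expected rather than none, so that compound 4 is estimated at 45000 nM, in the range 18000 nM to 110000 nM. The expected step from compound 3 is a 2.4-fold lower number from compound 3 to compound 4 (0.38 log units; beyond the scatter).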

Compound 4, half-maximal inhibitory concentration: 216000 nM
Compound 4: middle estimate off by 4.8-fold (0.68 log units), on the low side; the whole stated range lies below it.
By their numbers in this assay, from the lowest: compound 1; then compounds 3, 4 and 2 (each within the scatter of the next, the first and the last beyond it).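

Extending the chain by one more carbon does not continue the earlier lowering in this assay (a 2.0-fold higher number from compound 3 to compound 4 (0.30 log units; within the scatter)), and this step lies within the scatter. The two-carbon extension, ethyl in place of hydrogen on a saturated chain carbon six bonds along the chain from the same atoms, also stays within the scatter (a 1.5-fold lower number from compound 2 to compound 4 (0.16 log units; within the scatter)), so chain length shows no steady trend across these three silyl cyanohydrins, and the beyond-scatter step (a 2.9-fold lower number from compound 2 to compound 3 (0.46 log units; beyond the scatter)) stands alone and goes against any such reading. No measurement shown bears on why the chain extension stops lowering the number.

Open, from the compounds shown here alone, is whether a longer chain than that of compound 4 would shift the number at all. Also open, going by these compounds, is whether a free hydroxyl in place of the silyl ether, or an aldehyde in place of the nitrile, would bring this chain series nearer to compound 1 (6000 nM).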